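Sulfoxide analogues of a xanthine-type monoamine oxidase B series

This account rests on a few compounds, and the source may have more. Where it says the series, first, only, none or still open, it means among the compounds named here.

Compound 1 `Cn1c(=O)c2c(nc(SCCc3ccc(Br)cc3)n2C)n(C)c1=O`: 19 nM
Compound 2 `COc1ccc(CCSc2nc3c(c(=O)n(C)c(=O)n3C)n2C)cc1`: 23 nM
Compound 3 `Cn1c(=O)c2c(nc([S+]([O-])CCc3ccc(Br)cc3)n2C)n(C)c1=O`: 471 nM

In an assay on microsomes for inhibition of Amine oxidase [flavin-containing] B (Homo sapiens), read by fluorescence and spectrophotometry, with a stated time of 20 min (a lower number here means a stronger inhibitor, a higher number a weaker inhibitor), compound 3 gives the highest number of the three, and its steps to compound 1 and compound 2 both lie beyond the scatter, so it is the weakest inhibitor measured. Compound 4 `Cn1c(=O)c2c(nc([S+]([O-])Cc3ccccc3)n2C)n(C)c1=O` differs from compound 3 by phenyl in place of 4-bromobenzyl on a saturated chain carbon bound to a sulfur. Among the measured compounds shown here, the only measured step, a 1.2-fold higher number from compound 1 to compound 2 (0.08 log units; within the scatter), concerns a substituent on the aromatic ring and says nothing about shortening the chain. For the measured compounds named here, no measured pair covers the change to compound 4, so the expectation rests on compound 3 alone, with wide uncertainty. Compound 4 is expected to remain a weak inhibitor, estimated at 1500 nM (range 400 nM to 6000 nM), a step of a 3.2-fold higher number from compound 3 to compound 4 (0.50 log units; beyond the scatter).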

Compound 4, half-maximal inhibitory concentration: 131000 nM
Beside the measured number, compound 4's estimate is 87-fold (1.94 log units) below it; measured number above the stated range.
By their numbers in this assay, from the lowest: compounds 1 and 2 (each within the scatter of the next); then compound 3; then compound 4.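

Among the compounds shown here, replacing 4-bromobenzyl with phenyl on a saturated chain carbon bound to a sulfur gives a 280-fold higher number from compound 3 to compound 4 (2.44 log units; beyond the scatter) and is the first change to move the number so sharply. The earlier ring change, a 1.2-fold higher number from compound 1 to compound 2 (0.08 log units; within the scatter), gave no sign of such sensitivity. No measurement bears on the reason for this large step. The compounds shown do not separate the loss of the bromine from the loss of the chain carbon. A 4-bromophenyl group or a longer chain at this place would address that question.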